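Methyl in Place of Chloro: An Estimated Partition Coefficient

The source may hold more compounds than are shown below. What is called first, only, known or untested is meant among the compounds shown, and "the series" means these compounds.

compound 1 `O=C(CSc1nc2ccccc2s1)N/N=C/c1ccc(Oc2ccc(Cl)cc2)cc1` 5.6
compound 2 `Cc1ccc(Oc2ccc(/C=N/NC(=O)CSc3nc4ccccc4s3)cc2)cc1` 5.7
compound 3 `Clc1ccc(Oc2ccc(/C=N/Nc3nc4ccccc4s3)cc2)cc1` 5.6

Of the compounds shown here, three have been measured in a physicochemical assay for lipophilicity, in phosphate buffer, measured as octanol-water partition, with a stated time of 24 h; a lower number here means a more polar compound, a higher number a more lipophilic compound. Compound 1 gives 5.6, compound 2 gives 5.7 and compound 3 gives 5.6. Compound 1 and compound 2 share one core and differ in a single place: methyl in place of chloro on an aromatic carbon. That change made a step of a number 0.10 log units higher from compound 1 to compound 2 (within the scatter). Compound 3 carries a different core; the difference between the two cores is not broken down here. Its value and that of compound 1 are level at the digits reported, and it stands within the scatter of compound 2 as well.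

Compound 4 `Cc1ccc(Oc2ccc(/C=N/Nc3nc4ccccc4s3)cc2)cc1` has not yet been measured in this assay. It differs from compound 3 in exactly one place: methyl in place of chloro on an aromatic carbon. This is the same change as that from compound 1 to compound 2, made at the same kind of place, and it occurs twice among the four compounds.

An estimate for compound 4 rests on that earlier pair. The step from compound 3 to compound 4 is expected to be a number 0.10 log units higher from compound 3 to compound 4 (within the scatter), because the same change gave a number 0.10 log units higher from compound 1 to compound 2 (within the scatter) on the core of compound 1. On that basis compound 4 is expected to give about 5.7, with a range from 5.4 to 6, in this assay.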

Compound 4, partition coefficient: 5.4
The estimate for compound 4 lay 0.30 log units above the measured number, within the range that was stated.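

In this assay, methyl in place of chloro on an aromatic carbon gave a number 0.20 log units lower from compound 3 to compound 4 (within the scatter), and the same change on the core of compound 1 gave a number 0.10 log units higher from compound 1 to compound 2 (within the scatter), so on both cores the step stays inside the usual variation between repeated measurements. Within the data shown here, this shows that, across these two pairs, carrying the change from one core to the other produced no step that can be told apart from that variation, but with only two pairs, neither of them beyond the scatter, it does not show that a direction or a size of step carries over, nor that it fails to. Nothing is available that bears on why the numbers fell as they did.

The compounds shown carry only chloro or methyl at this place, so it remains open whether an amine, a carboxylic acid or a longer chain on the same aromatic carbon would give a step beyond the scatter on either core. It also remains open whether the change from 4-chlorophenoxy to 4-methylphenoxy would stay within the scatter on any further core, since these two cores are the only ones shown.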